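The compounds below may be only part of what the source reports. "The series", "measured", "known", "first", "only" and "open" are said of these compounds alone.

Compound 2 `Cc1ccc(-n2nncc2CN2C(=O)C3(C(C#N)=C(N)Oc4c(N)cc5nc6ccccc6nc5c43)c3ccccc32)cc1Cl` belongs to a small group of compounds built on one shared core and tested in an ADME assay on HUVEC cells (Homo sapiens) for antiproliferative activity, read by MTT assay, with a stated time of 48 h; a lower number here means a stronger inhibitor, a higher number a weaker inhibitor. In this assay compound 2 gives only a limit, > 50000 nM. Within the data shown here, its one measured neighbour, compound 1 `CCOc1ccccc1-n1nncc1CN1C(=O)C2(C(C#N)=C(N)Oc3c(N)cc4nc5ccccc5nc4c32)c2ccccc21`, differs from it solely in the group carried on an aromatic nitrogen. In this assay compound 1 likewise gives only a limit, > 50000 nM. The step that the two limits leave unreadable from compound 1 to compound 2 therefore cannot be read as a number at all. the limit of > 50000 nM in this assay, at which 2 of the 2 values shown sit, is the whole of what these two measurements reveal.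

Compound 3 `N#CC1=C(N)Oc2c(N)cc3nc4ccccc4nc3c2C12C(=O)N(Cc1cnnn1-c1ccc(F)c(Cl)c1)c1ccccc12` is the compound still to be measured. It differs from compound 2 in one place: fluoro in place of methyl on an aromatic carbon. Among the measured compounds shown here, no measured step bears directly on this change, and the one step that exists between measured compounds is itself unreadable. With both known values sitting at the same limit, compound 3 is expected to sit at that limit as well, so the step that the limit leaves unreadable from compound 2 to compound 3 is expected to have no readable size. The estimate for compound 3 in this assay is 60000 nM, within a range from 20000 nM to 200000 nM.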

Compound 3, half-maximal inhibitory concentration: > 50000 nM
Compound 3 ended at the assay's limit (the forecaster's own chance of this, stated with the estimate: 80%); the middle value is on the limit's open side.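

Compound 3 also gives only a limit in this assay, so its steps from compound 2 and from compound 1 cannot be read as sizes: the limit of > 50000 nM in this assay, at which 3 of the 3 values shown sit.

The compounds shown leave open how strongly any of the three acts in these cells, and whether swapping these groups on the shared core changes that activity at all.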